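Ring expansion and demethylation of the basic amine in compound 1

The source may hold more compounds than are shown below. What is called first, only, known or untested is meant among the compounds shown, and "the series" means these compounds.

Measured so far:
compound 1, `CN1CCC(n2cc(S(=O)(=O)c3ccccc3)c3cccnc32)C1`, 2.5 nM
compound 2, `CN1CCC(n2cc(S(=O)(=O)c3ccccc3F)c3cccnc32)C1`, 5.6 nM

Compound 1 holds the lowest of the two numbers in an assay on HeLa cells for displacement of a labelled ligand from 5-hydroxytryptamine receptor 6 (Homo sapiens); on this read-out lower numbers stand for stronger inhibition and higher numbers for weaker inhibition; the nearest is compound 2, which sits a 2.2-fold higher number from compound 1 to compound 2 (0.35 log units; beyond the scatter) away, a change brought by fluoro in place of hydrogen on an aromatic carbon. Compound 3, `O=S(=O)(c1ccccc1)c1cn(C2CCCNC2)c2ncccc12`, has not been measured. It differs from compound 1 by piperidin-3-yl in place of 1-methylpyrrolidin-3-yl on an aromatic nitrogen. For the measured compounds named here, the only measured step concerns the sulfonyl-bearing aromatic ring, not the amine, so no step bears directly on this change. With the basic nitrogen kept and its ring enlarged by one member while the methyl is lost, a change of about a 1.6-fold higher number from compound 1 to compound 3 (0.20 log units; within the scatter) is expected, within or near the scatter. Compound 3 is therefore estimated at 4 nM, ranging from 1 nM to 15 nM in this assay.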

Compound 3, inhibition constant: 4.9 nM
For compound 3 the middle estimate is 1.2-fold (0.09 log units) below the measured one; the range from low to high includes it.
By their numbers in this assay, from the lowest: compounds 1, 3 and 2 (each within the scatter of the next, the first and the last beyond it).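

In this assay piperidin-3-yl in place of 1-methylpyrrolidin-3-yl on the aromatic nitrogen gives a 2.0-fold higher number from compound 1 to compound 3 (0.29 log units; within the scatter) and so leaves the two compounds indistinguishable on this read-out. For the compounds shown here, this is the first reading at this position, as the earlier step concerned only the sulfonyl-bearing aromatic ring, and it shows that a six-membered non-aromatic ring with 1 hydrogen-bond donor is tolerated here in place of a five-membered one with 0 donors. No supporting data bear on why the two values stay within the scatter.

The ring enlargement and the loss of the methyl occur in a single step, so their separate contributions cannot be read. Pyrrolidin-3-yl and 1-methylpiperidin-3-yl at this position would each isolate one of these changes, and how a longer chain such as ethyl on the ring nitrogen would read remains open.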